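The source may report more compounds than this note shows. Statements on the series, on what has been measured and on what is new or still open speak of the compounds shown alone.

Measured so far in a functional assay on SK-MEL-2 cells (Homo sapiens) for inhibition, read by sulforhodamine B assay, with a stated time of 48 h; on this read-out lower numbers stand for higher toxicity in this test and higher numbers for lower toxicity in this test:
compound 1 `COc1ccc(C(=O)/C=C/c2cc(-c3cc(OC)c(OC)c(OC)c3)n[nH]2)cc1OC` gives 6680 nM
compound 2 `COc1ccc(C(=O)/C=C/c2cc(-c3cc(OC)c(OC)c(OC)c3)n[nH]2)cc1` gives 99200 nM

Among the compounds with values here, compound 1 holds the lower of the two numbers; the one measured step, a 15-fold higher number from compound 1 to compound 2 (1.17 log units; beyond the scatter), separates it from the other, and that step is a single change on the aromatic ring that carries the carbonyl: hydrogen in place of methoxy on an aromatic carbon.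

Compound 3 `COc1cc(C(=O)/C=C/c2cc(-c3cc(OC)c(OC)c(OC)c3)n[nH]2)cc(OC)c1OC` is not yet measured. It differs from compound 1 by methoxy in place of hydrogen on an aromatic carbon. Within the data shown here, the only step that bears on this change runs the opposite way, a 15-fold higher number from compound 1 to compound 2 (1.17 log units; beyond the scatter): removing a methoxy from the same ring gave a large rise in the number. Adding a further methoxy is therefore expected to move the number down rather than up, but a third methoxy need not repeat the size of that step, so a moderate fall, a 2.2-fold lower number from compound 1 to compound 3 (0.35 log units; beyond the scatter), is expected. For compound 3 in this assay the estimate is 3000 nM, range 800 nM to 15000 nM.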

Compound 3, concentration lethal to 50% of the cells: 8320 nM
Estimate against measurement, compound 3: 2.8-fold (0.44 log units) below; low and high end bracket the measured number.
By their numbers in this assay, from the lowest: compounds 1 and 3 (each within the scatter of the next); then compound 2.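

In this assay, methoxy in place of hydrogen on this aromatic carbon, ortho to a methoxy group, gives a 1.2-fold higher number from compound 1 to compound 3 (0.10 log units; within the scatter), so this further methoxy leaves the number unresolved from that of compound 1. On the same ring, the earlier change gave a 15-fold higher number from compound 1 to compound 2 (1.17 log units; beyond the scatter), so the size of one methoxy change on this ring does not carry over to the next, and the large step does not extend to this position. No measurement on hand accounts for the difference between these two changes.

Going by these compounds, whether this carbon tolerates only hydrogen and methoxy stays open, since a hydroxyl, an amine or a longer chain such as ethoxy at the same place would test how much room the series has there. Also open, on these data alone, is whether the same flat result holds when the methoxy groups elsewhere on the shared core are changed.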